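Notes on one amide series: swapping the sulfur-linked group

This account rests on a few compounds, and the source may have more. Where it says the series, first, only, none or still open, it means among the compounds named here.

Measured so far in a functional assay on HT-29 cells (Homo sapiens) for cytotoxicity, read by MTT assay, with a stated time of 24 h, tested at 1.6 ug/mL; a lower number here means a weaker effect, a higher number a stronger effect of the compound at the concentration tested:
- compound 1 `Cn1c(-c2ccc(NC(=O)CSc3nc4ccccc4o3)cc2)nc(-c2ccccc2)c1-c1ccccc1` gives 41%
- compound 2 `Cn1c(-c2ccc(NC(=O)CSc3nc4ccccc4s3)cc2)nc(-c2ccccc2)c1-c1ccccc1` gives 15.3%
- compound 3 `Cn1cnnc1SCC(=O)Nc1ccc(-c2nc(-c3ccccc3)c(-c3ccccc3)n2C)cc1` gives 40.8%

Compound 2 stands lowest of the three numbers in this assay. Its nearest neighbour is compound 3, and its furthest is compound 1, both beyond the scatter. The two measured steps touching compound 2 are a number 25.7 percentage points lower from compound 1 to compound 2 (beyond the scatter) and a number 25.5 percentage points higher from compound 2 to compound 3 (beyond the scatter), each a modest step; the remaining step, a number 0.2 percentage points lower from compound 1 to compound 3 (within the scatter), lies within the scatter.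

Compound 4 `CN1CCN(CC(=O)Nc2ccc(-c3nc(-c4ccccc4)c(-c4ccccc4)n3C)cc2)CC1` is the next candidate for this assay. Against compound 2 the change is 4-methylpiperazin-1-yl in place of (1,3-benzothiazol-2-yl)sulfanyl on a saturated chain carbon bound to a carbonyl carbon. Neither measured step covers this kind of replacement: both only exchanged one ring on the sulfur for another, while here the sulfur and its ring leave together and a saturated ring enters. The bearing steps therefore say only that moving away from the 1,3-benzothiazol-2-yl group has so far given a modest rise, as seen from compound 2 to compound 3, and that compound 2 is the outlier among the three.

On that basis a modest rise a number 14.7 percentage points higher from compound 2 to compound 4 (beyond the scatter) is expected for compound 4, with a wide range given the untested nature of the change. Compound 4 is estimated at 30%, between 10% and 50%.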

Compound 4, a percentage reported as activity, at one concentration (the size of the read-out at that concentration, not a potency): 27.4%
For compound 4 the middle estimate is 2.6 percentage points above the measured one, and the stated range covers the measured number.
By their numbers in this assay, from the lowest: compound 2; then compound 4; then compounds 3 and 1 (each within the scatter of the next).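

In this assay, the place on a saturated chain carbon bound to a carbonyl carbon proves open to more than an exchange of rings on the sulfur: the sulfur and its ring can leave together, and the saturated 4-methylpiperazin-1-yl group still gives a clear read-out, with a number 12.1 percentage points higher from compound 2 to compound 4 (beyond the scatter) as the step from the benzothiazole compound. The direction of this replacement depends on the group that leaves, since the same 4-methylpiperazin-1-yl group gives a number 13.4 percentage points lower from compound 3 to compound 4 (beyond the scatter) and a number 13.6 percentage points lower from compound 1 to compound 4 (beyond the scatter) as the steps from the two other sulfur-linked compounds. Among these four compounds, then, loss of the sulfur does not by itself set the direction of the step, and compound 4 takes a place of its own in the series. No measurement shown here explains any of these steps.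

Open, going by these compounds, is whether the rise and falls seen with 4-methylpiperazin-1-yl are specific to that ring, or would also appear with morpholin-4-yl or an open-chain dimethylamino group at the same place. Also open, on these data alone, is how a longer chain between the carbonyl and the ring would read, and whether these differences at a single concentration would hold as differences in potency.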